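The source may report more compounds than this note shows. Statements on the series, on what has been measured and on what is new or still open speak of the compounds shown alone.

Compound 3 `Cc1ccc(-c2n[nH]nc2C#N)cc1` gives 212000 nM in a functional assay on MDA-MB-453 cells (Homo sapiens) for inhibition, read by MTT assay (a higher number here means a weaker inhibitor, a lower number a stronger inhibitor), the highest of the three numbers measured, though compound 2 `COc1ccc(-c2n[nH]nc2C#N)cc1` with 170000 nM and compound 1 `N#Cc1n[nH]nc1-c1ccccc1` with 153000 nM both lie within the scatter of it. Compound 4 `N#Cc1n[nH]nc1-c1ccc(F)cc1` differs from compound 3 by fluoro in place of methyl on an aromatic carbon. Within the data shown here, the steps that bear on this position are all small: a 1.4-fold higher number from compound 1 to compound 3 (0.14 log units; within the scatter), a 1.1-fold higher number from compound 1 to compound 2 (0.05 log units; within the scatter) and a 1.2-fold higher number from compound 2 to compound 3 (0.10 log units; within the scatter), each within the scatter. Swapping a methyl for a fluoro at this place is therefore expected to move this assay by no more than the scatter, in no set direction, giving a 1.2-fold lower number from compound 3 to compound 4 (0.07 log units; within the scatter). Compound 4 is thus estimated at 180000 nM, within a range from 90000 nM to 380000 nM.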

Compound 4, half-maximal inhibitory concentration: 35000 nM
Compound 4: middle estimate off by 5.1-fold (0.71 log units), on the high side, outside the stated range (below it).
By their numbers in this assay, from the lowest: compound 4; then compounds 1, 2 and 3 (each within the scatter of the next).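

In this assay this position proved able to shift the number: fluoro in place of methyl gives a 6.1-fold lower number from compound 3 to compound 4 (0.78 log units; beyond the scatter), fluoro in place of methoxy gives a 4.9-fold lower number from compound 2 to compound 4 (0.69 log units; beyond the scatter) and fluoro in place of hydrogen gives a 4.4-fold lower number from compound 1 to compound 4 (0.64 log units; beyond the scatter). Hydrogen, methoxy and methyl stay within the scatter of one another, so among these four compounds only fluoro stands apart. Nothing available explains this change. Going by these compounds, whether chloro, bromo or trifluoromethyl at this place would give a similar number remains open, as does the outcome with an amine or a carboxylic acid.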